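Replacing the Chloropyridine of Compound 2 with a Methylpyridine

This account rests on a few compounds, and the source may have more. Where it says the series, first, only, none or still open, it means among the compounds named here.

In a physicochemical assay for solubility, read by HPLC, measured as thermodynamic solubility, with a stated time of 4 h, at pH 6.8 (a higher number here means a more soluble compound, a lower number a less soluble compound), compound 1 `Cc1ccc(Oc2cc3c(cn2)nc(COc2cccc(C(=O)O)c2)n3C)cc1` reads 360 ug/mL and compound 2 `Cn1c(COc2cccc(C(=O)O)c2)nc2ccc(Oc3ccc(Cl)cn3)cc21` reads 17 ug/mL as the lower of the two numbers, a gap beyond the scatter. Compound 3 `Cc1cccc(Oc2ccc3nc(COc4cccc(C(=O)O)c4)n(C)c3c2)n1` has not yet been measured. It differs from compound 2 by 6-methylpyridin-2-yl in place of 5-chloropyridin-2-yl on an oxygen on an aromatic ring with 6-methylpyridin-2-yl in place of 5-chloropyridin-2-yl on an oxygen on an aromatic ring. Going by the values given here, compound 1 and compound 2 differ in more than one place, so no measured step speaks directly for this change. With compound 2 at 17 ug/mL as the lower number and compound 1 at 360 ug/mL as the only higher one, a modest upward move is expected. The expected change is a 2.4-fold higher number from compound 2 to compound 3 (0.37 log units; beyond the scatter) in this assay and may land close to the scatter. For compound 3 the estimate is 40 ug/mL with an expected range from 12 ug/mL to 140 ug/mL for the measurement.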

Compound 3, solubility: 92 ug/mL
Compound 3: middle estimate off by 2.3-fold (0.36 log units), on the low side, within the range that was stated.
By their numbers in this assay, from the lowest: compound 2; then compound 3; then compound 1.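

In this assay, 6-methylpyridin-2-yl in place of 5-chloropyridin-2-yl on an oxygen on an aromatic ring gives a 5.4-fold higher number from compound 2 to compound 3 (0.73 log units; beyond the scatter), which shows that the group at this place alone can move the number beyond the scatter while the rest of the molecule stays the same. The change swaps chlorine for methyl and also alters where the substituent stands on the pyridine, as the two names show, so this single step cannot separate those two differences. No measurement shown accounts for the step. The compounds shown leave open whether the step follows the methyl or its place on the ring, a question that 5-methylpyridin-2-yl on the same oxygen would address. As far as these compounds go, how a methoxy group or an amine on that pyridine would read in this assay also remains open.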